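Hydroxy to methoxy: expected effect on compound 3

The source may report more compounds than this note shows. Statements on the series, on what has been measured and on what is new or still open speak of the compounds shown alone.

In a functional assay on HT-29 cells (Homo sapiens) for inhibition, with a stated time of 72 h (on this read-out higher numbers stand for weaker inhibition and lower numbers for stronger inhibition), compound 1 `COc1ccc(S(=O)(=O)N2CCc3cccc(-c4ccc(O)cc4)c32)cc1` gives 133 nM, the lower of the two numbers obtained so far. Compound 2 `COc1ccc(S(=O)(=O)N2CCc3cccc(-c4c(F)c(F)c(F)c(F)c4F)c32)cc1` gives in this assay 3900 nM, a higher number whose gap to compound 1 lies beyond the usual scatter. Compound 3 `COc1ccc(-c2cccc3c2N(S(=O)(=O)c2ccc(OC)cc2)CC3)cc1` has not yet been tested in this assay. It differs from compound 1 by a single change: methyl in place of hydrogen on an oxygen on an aromatic ring. For the measured compounds named here, no measured pair shows this change, so its direction is unknown here. The step of a 3.0-fold higher number from compound 1 to compound 3 (0.48 log units; beyond the scatter) is estimated as modest, toward a higher number. Compound 3 is expected to give about 400 nM, within 100 nM to 2000 nM.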

Compound 3, half-maximal inhibitory concentration: 277 nM
The estimate for compound 3 lay 1.4-fold (0.16 log units) above the measured number; the measured number falls inside the stated range.
By their numbers in this assay, from the lowest: compound 1; then compound 3; then compound 2.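

In this assay, for the compounds shown here, the change from hydroxy to methoxy on the 4-hydroxyphenyl group gives a 2.1-fold higher number from compound 1 to compound 3 (0.32 log units; beyond the scatter), the first direct reading at this oxygen. Inhibition persists with the hydrogen replaced by methyl, so the free hydroxy is not required for activity here, although the step is modest and lies beyond the scatter. No measurement at hand gives a cause for this step. From the compounds shown here alone, it remains open whether a longer chain on this oxygen, such as ethoxy, would extend the same trend. Also open, going by these compounds, is how an amine or a carboxylic acid in place of hydroxy would read.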